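A Bromine Added to Compound 2: Expected Effect on Paw Swelling

This account rests on a few compounds, and the source may have more. Where it says the series, first, only, none or still open, it means among the compounds named here.

Compound 2 `c1ccc(NCc2nc3ccccc3[nH]2)cc1` is the plainest member of this small set. In a functional assay on the whole organism (strain albino) for inhibition, with Rattus norvegicus as the target, read by paw edema, with a stated time of 60 min, at a dose of 100 mg/kg by the oral route (a lower number here means less inhibition, a higher number more inhibition at the dose given (going by the name of the read-out)), compound 2 gives 26.6%. It stands level with both of its neighbours: compound 1 `Clc1cccc(NCc2nc3ccccc3[nH]2)c1` gives 26.6% and compound 3 `Brc1ccc2nc(CNc3ccccc3)[nH]c2c1` gives 26.6%, both in this assay. Compound 4 `Brc1ccc(NCc2nc3ccccc3[nH]2)cc1` differs from compound 2 by bromo in place of hydrogen on an aromatic carbon. Going by the values given here, two measured steps bear on this change. The step of no change at the digits printed from compound 1 to compound 2 (within the scatter) removes a chloro from an aromatic carbon, and the step of no change at the digits printed from compound 2 to compound 3 (within the scatter) adds a bromo on an aromatic carbon of the shared core; neither moved the read-out beyond the scatter. A similar outcome is therefore expected here, with the step of no change at the digits printed from compound 2 to compound 4 (within the scatter) expected to stay within the scatter. Compound 4 is estimated at 26.6%, with an expected range from 16% to 38%.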

Compound 4, a percentage reported as inhibition, in the whole organism at one dose (the size of the read-out at that dose, not a potency): 13.3%
Beside the measured number, compound 4's estimate is 13.3 percentage points above it; measured number outside the range, below it.
By their numbers in this assay, from the lowest: compound 4; then compounds 1, 2 and 3 (each within the scatter of the next).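

In this assay the step of a number 13.3 percentage points lower from compound 2 to compound 4 (beyond the scatter) shows that bromo in place of hydrogen is not a neutral change on this ring, a six-membered aromatic ring of carbon only, para to a large group. The same replacement on the shared core gave no change at the digits printed from compound 2 to compound 3 (within the scatter) instead, so among these compounds the outcome depends on where the bromo sits. Nothing available here explains the lower inhibition of compound 4. Still open, going by these compounds, is whether a smaller chloro, an amine or a carboxylic acid at this place would lower the read-out as well.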